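This account rests on a few compounds, and the source may have more. Where it says the series, first, only, none or still open, it means among the compounds named here.

Working notes on the series. Compound 1 `C#CCCCn1c(Cc2cc(OC)c(OC)c(OC)c2)nc2c(N)ncnc21` is the starting point of this step. In a functional assay on MCF7 cells (Homo sapiens) for antiproliferative activity (a higher number here means a weaker inhibitor, a lower number a stronger inhibitor), compound 1 gives 24000 nM. Compound 2 `CCCCn1c(Cc2cc(OC)c(OC)c(OC)c2)nc2c(N)nc(F)nc21` gives 24000 nM in this assay, so compound 1 stands level with compound 2 at the digits shown, and these two together give the lowest numbers of the three measured. Compound 3 `CCCn1c(Cc2cc(OC)c(OC)c(OC)c2)nc2c(N)nc(F)nc21` gives 25100 nM in this assay, a number within the scatter of compound 1 and of compound 2; nothing separates the three beyond the usual repeat variation.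

Among the compounds with values here, the one step between measured compounds differing in a single place is a 1.0-fold higher number from compound 2 to compound 3 (0.02 log units; within the scatter). It concerns the chain on the aromatic nitrogen, but the exchange it reads is not the one considered next.

Compound 4 `CC/C=C/Cn1c(Cc2cc(OC)c(OC)c(OC)c2)nc2c(N)ncnc21` has not been measured. It differs from compound 1 by but-1-en-1-yl in place of but-3-yn-1-yl on a saturated chain carbon bound to an aromatic nitrogen. Within the data shown here, no measured pair carries this exchange of an unsaturation in the chain, so the only guidance is that the one recorded chain alteration, a 1.0-fold higher number from compound 2 to compound 3 (0.02 log units; within the scatter), stayed within the scatter. On that basis a step of no size beyond the scatter is expected, in no particular direction. The step of no change at the digits printed from compound 1 to compound 4 (within the scatter) is the expectation. Compound 4 is therefore estimated at 24000 nM, with a range from 9000 nM to 65000 nM.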

Compound 4, half-maximal inhibitory concentration: 46800 nM
Beside the measured number, compound 4's estimate is 2.0-fold (0.29 log units) below it; low and high end bracket the measured number.
By their numbers in this assay, from the lowest: compounds 1, 2, 3 and 4 (each within the scatter of the next).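

Within the data shown here, compound 4 gives the first reading of a triple bond exchanged for a double bond at this place, on a saturated chain carbon bound to an aromatic nitrogen. In this assay the exchange of but-3-yn-1-yl for but-1-en-1-yl gives a 2.0-fold higher number from compound 1 to compound 4 (0.29 log units; within the scatter), so the two chains cannot be told apart in this assay, and the kind of unsaturation and its place along the chain have no effect here that rises above repeat variation. This extends what the chain alteration from a 1.0-fold higher number from compound 2 to compound 3 (0.02 log units; within the scatter) showed for a saturated chain on the fluorine-bearing compounds to a pair without fluorine, though nothing on hand bears on why the number stays in this range.

Still open, on these data alone, is whether any group at this place moves the number beyond the scatter, for instance a terminal amine, a carboxylic acid or a much longer chain ending in a hydroxyl group. Also open, as far as these compounds go, is whether the exchange from but-3-yn-1-yl to but-1-en-1-yl reads the same on a core carrying the fluorine of compound 2.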